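Working notes: cytotoxicity of compound 1 and its analogues

The compounds below may be only part of what the source reports. "The series", "measured", "known", "first", "only" and "open" are said of these compounds alone.

Measured so far in a functional assay on cells (Homo sapiens) for cytotoxicity; on this read-out higher numbers stand for lower toxicity in this test and lower numbers for higher toxicity in this test:
Compound 1 `O=C1N(CCCCCCOc2ccc(Br)cc2)CCN1c1ccncc1` gives > 25000 nM, which is a limit of the assay and not a number.
Compound 2 `O=C1N(CCCCCCOc2cccc(Br)c2)CCN1c1ccncc1` gives > 25000 nM, again a limit.
Compound 3 `O=C1N(CCCCCCOc2c(Cl)cccc2Cl)CCN1c1ccncc1` gives > 25000 nM, again a limit.

Compound 1 thus stands where every measured compound stands: at the limit of > 25000 nM in this assay, at which 3 of the 3 values shown sit. Because all three values are limits, the steps a step that the two limits leave unreadable from compound 1 to compound 2, a step that the two limits leave unreadable from compound 1 to compound 3 and a step that the two limits leave unreadable from compound 2 to compound 3 have no readable size, and no order among the three can be stated.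

Compound 4 `O=C1N(CCCCCCOc2ccc(Br)cc2)CCN1c1cccnc1` differs from compound 1 by pyridin-3-yl in place of pyridin-4-yl on an amide-type nitrogen in a ring. Within the data shown here, none of the measured steps changes this part of the shared core; each of them alters only the group on an oxygen on a saturated carbon, and none has a readable size. Among the measured compounds shown here, no measured step therefore bears on the change from compound 1 to compound 4, and none gives grounds to expect movement. For the estimated step that the limit leaves unreadable from compound 1 to compound 4 no size beyond the scatter is expected in this assay. Compound 4 is expected at 30000 nM, with a range from 12000 nM to 80000 nM, and most likely reported once more only as a limit.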

Compound 4, half-maximal cytotoxic concentration: > 25000 nM
Compound 4 was reported as a limit; the forecaster's own chance of this, stated with the estimate: 85%; the middle value lies beyond the limit too.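

No size can be read for the change from compound 1 to compound 4 in this assay, since both values are limits and not numbers: the limit of > 25000 nM in this assay, at which 4 of the 4 values shown sit.

The compounds shown leave open at what concentration any of them turns cytotoxic, and whether pyridin-3-yl and pyridin-4-yl differ at all on this read-out.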